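A few compounds are considered here, and "the series" means these few. Any claim that something is new, unique, unknown or untested is made for them only; others in the source may bear on it.

In a functional assay on HL-60 cells (Homo sapiens) for inhibition, read by resazurin assay, with a stated time of 72 h (on this read-out lower numbers stand for stronger inhibition and higher numbers for weaker inhibition), three compounds have been measured so far. Compound 1 (`COc1cc(N2C(=O)CC2c2ccc(SC)cc2)cc(OC)c1OC`) gives 69 nM and compound 3 (`CCOc1ccc(C2C(C3CC3)C(=O)N2c2cc(OC)c(OC)c(OC)c2)cc1`) gives 201 nM while compound 2 (`COc1ccc(C2C(O)C(=O)N2c2cc(OC)c(OC)c(OC)c2)cc1`) gives 13 nM as the lowest number of the three, beyond the scatter against both of the others. Within the data shown here, these compounds differ in more than one place, so no single-change step is available to guide a prediction. Compound 4 (`COc1ccc(C2C(O)C(=O)N2c2cc(OC)c(OC)c(OC)c2)cc1O`) is compound 2 with one change, 4-methoxyphenyl to 3-hydroxy-4-methoxyphenyl. Hydroxy stands in place of hydrogen on an aromatic carbon (hydroxy in place of hydrogen on an aromatic carbon), ortho to a methoxy group. Among the measured compounds shown here, no measured pair shows this change, so the expectation is a loose one: a modest move toward stronger inhibition, with a step of no size ruled out. The estimated change is a 2.2-fold lower number from compound 2 to compound 4 (0.34 log units; beyond the scatter) toward a lower number. For compound 4 the expected value is 6 nM within an estimated range of 1.5 nM to 30 nM and it remains an estimate until the measurement is in.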

Compound 4, half-maximal inhibitory concentration: 5 nM
The estimate for compound 4 lay 1.2-fold (0.08 log units) above the measured number; the range from low to high includes it.
By their numbers in this assay, from the lowest: compound 4; then compound 2; then compound 1; then compound 3.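

In this assay, among these compounds, a 2.6-fold lower number from compound 2 to compound 4 (0.41 log units; beyond the scatter) gives the first reading of a single change, which the earlier compounds, differing in more than one place, could not provide. It shows that the 4-methoxyphenyl group tolerates a hydroxy group on an aromatic carbon ortho to its methoxy group, and that inhibition grows stronger rather than being lost with this added group. Nothing available here explains why the number falls with this change.

The compounds shown leave open whether this gain is specific to hydroxy, since an amine or a fluorine atom at the same place would be needed to tell. They also leave open whether the same change would lower the number on the different frameworks of compound 1 and compound 3.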